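A few compounds are considered here, and "the series" means these few. Any claim that something is new, unique, unknown or untested is made for them only; others in the source may bear on it.

Measured compounds:
Compound 1 `Nc1ccc(-c2cc(=O)c3c(N)c(F)c(O)c(F)c3o2)cc1F` gives > 10000 nM in a functional assay on MCF7 cells (Homo sapiens) for cytotoxicity, read by neutral red uptake, with a stated time of 3 days (on this read-out higher numbers stand for weaker inhibition and lower numbers for stronger inhibition), a limit of the assay.
Compound 2 `Nc1ccc(-c2cc(=O)c3c(N)c(F)c(C(=O)O)c(F)c3o2)cc1F` gives > 10000 nM in this assay, again a limit.

Compound 2 thus stands at the edge of what this assay can report, and only a limit is known for it. Going by the values given here, the one step among the measured compounds, a step that the two limits leave unreadable from compound 1 to compound 2, is carboxy in place of hydroxy on an aromatic carbon; since both compounds sit at the same limit (the limit of > 10000 nM in this assay, at which 2 of the 2 values shown sit), its size cannot be read, and it shows only that neither compound reached a measurable value.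

Compound 3 `CCCOCc1c(F)c(N)c2c(=O)cc(-c3ccc(N)c(F)c3)oc2c1F` differs from compound 2 by propoxymethyl in place of carboxy on an aromatic carbon. Among the compounds with values here, no measured step describes this exchange, and the one step available is unreadable, so the data give no direction for this assay. Within the data shown here, the only guide is that compound 2 already sits at the limit of this assay; compound 3 is therefore expected to remain weak, with an estimated step that the limit leaves unreadable from compound 2 to compound 3. The estimate for compound 3 in this assay is 20000 nM, within a range from 5000 nM to 80000 nM, and most likely the assay will again report only a limit.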

Compound 3, half-maximal inhibitory concentration: 1200 nM
The estimate for compound 3 lay 17-fold (1.22 log units) above the measured number; the whole stated range lies above it.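

Compound 3 is the first compound here to give a number in this assay rather than a limit, so the aromatic carbon ortho to two fluoro groups is now shown to be a place where the group can change the read-out. Exchanging carboxy for propoxymethyl there gives an at least 8.3-fold lower number from compound 2 to compound 3 (0.92 log units; beyond the scatter), and exchanging hydroxy for propoxymethyl at the same carbon gives an at least 8.3-fold lower number from compound 1 to compound 3 (0.92 log units; beyond the scatter), so the two earlier groups, which could not be told apart, now share the same comparison with one measured compound. Both steps are minimum sizes, since each starts from a limit: the limit of > 10000 nM in this assay, at which 2 of the 3 values shown sit.

With propoxymethyl as the only group at this carbon that gives a number, the compounds shown cannot tell whether the lower number belongs to the whole chain or to one part of it, such as its ether oxygen. Also open, as far as these compounds go, is how a shorter methoxymethyl chain, a plain propyl chain without the oxygen, a longer butoxymethyl chain or an amine would read at this same carbon on the shared core.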